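The source may hold more compounds than are shown below. What is called first, only, known or untested is meant among the compounds shown, and "the series" means these compounds.

The measured compounds, with their results in a functional assay on MCF7 cells (Homo sapiens) for cytotoxicity, read by MTT assay, with a stated time of 72 h; on this read-out lower numbers stand for stronger inhibition and higher numbers for weaker inhibition:

Compound 1, `CNC(=O)c1cc(Oc2ccc(NC(=O)c3cc(-c4ccc(F)cc4)ncn3)cc2F)ccn1`, gives > 100000 nM, a limit of the assay.
Compound 2, `CNC(=O)c1cc(Oc2ccc(NC(=O)c3cc(-c4ccc(Cl)cc4)ncn3)cc2)ccn1`, gives > 100000 nM, also a limit of the assay.
Compound 3, `CNC(=O)c1cc(Oc2ccc(NC(=O)c3cc(-c4ccc(C)cc4)ncn3)cc2)ccn1`, gives 34600 nM.

Going by the values given here, compound 3 therefore holds the only actual number among the three; the other two sit at the limit of > 100000 nM in this assay, at which 2 of the 3 values shown sit. Among the compounds with values here, the one comparison that can be counted is an at least 2.8-fold lower number from compound 2 to compound 3 (0.46 log units; beyond the scatter), where a methyl replaced a chloro on the aromatic carbon, and the number fell at least modestly.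

Compound 4, `CNC(=O)c1cc(Oc2ccc(NC(=O)c3cc(-c4ccc(F)cc4)ncn3)cc2)ccn1`, is reached from compound 3 by fluoro in place of methyl on an aromatic carbon. This undoes the kind of change seen from compound 2 to compound 3, though with fluoro rather than chloro, and compound 1, which carries the same fluoro on that ring plus one more fluorine elsewhere, also rests at the limit. The expectation is therefore a step back upward in this assay, a 2.9-fold higher number from compound 3 to compound 4 (0.46 log units; beyond the scatter), quite possibly ending at the limit again. Compound 4 is estimated at 100000 nM, within a range from 35000 nM to 300000 nM.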

Compound 4, half-maximal inhibitory concentration: > 100000 nM
Compound 4: a limit, no number (the forecaster's own chance of this, stated with the estimate: 55%); the middle value lies on the limit itself.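

In this assay, the swap from 4-methylphenyl to 4-fluorophenyl gives an at least 2.8-fold higher number from compound 3 to compound 4 (0.46 log units; beyond the scatter), so fluoro now joins chloro in leaving the limit as the only result at this place, and methyl is the only group shown here that yields a number. Compound 4 also lacks the extra fluorine of compound 1 yet still ends at the limit, so that extra fluorine is not needed for this outcome. The steps to compound 4 from compound 2 and from compound 1 cannot be read, with limits at both ends: the limit of > 100000 nM in this assay, at which 3 of the 4 values shown sit.

Going by these compounds, whether an ethyl chain or an amine at this place would give a lower number than compound 3 stays open. On these data alone, with a single real number, how far the number can fall at this position also remains unknown.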